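The source may report more compounds than this note shows. Statements on the series, on what has been measured and on what is new or still open speak of the compounds shown alone.

Measured so far in an assay on CHO cells for antagonist activity at transient receptor potential cation channel subfamily V member 1 (Homo sapiens), read by FLIPR; on this read-out higher numbers stand for weaker inhibition and lower numbers for stronger inhibition: compound 1 `CCCN(CCC)c1cc(C(F)(F)F)ccc1CNC(=O)C(C)c1ccc(NS(C)(=O)=O)c(F)c1` gives 0.3 nM; compound 2 `CC(C(=O)NCc1ccc(C(F)(F)F)cc1N1CCN(C2CCCCC2)CC1)c1ccc(NS(C)(=O)=O)c(F)c1` gives 13.8 nM.

Among the measured compounds shown here, compound 2 stands at the higher of the two numbers; its only neighbour is compound 1, and the one measured step, a 46-fold higher number from compound 1 to compound 2 (1.66 log units; beyond the scatter), separates them. That step is the only one available and it is large.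

Compound 3 `CC(C)CCOc1cc(C(F)(F)F)ccc1CNC(=O)C(C)c1ccc(NS(C)(=O)=O)c(F)c1` is the next member. It differs from compound 2 in one place: isopentyloxy in place of 4-cyclohexylpiperazin-1-yl on an aromatic carbon. The change thus removes the same 4-cyclohexylpiperazin-1-yl group that entered in the step from compound 1 to compound 2 and puts a short chain group in its place, as compound 1 also carries a chain-type group there. The step that bears on this is a 46-fold higher number from compound 1 to compound 2 (1.66 log units; beyond the scatter); isopentyloxy is not identical to dipropylamino, so the reversal need not be complete. A clear drop in the number is expected for compound 3, in this assay at roughly a 12-fold lower number from compound 2 to compound 3 (1.06 log units; beyond the scatter). Compound 3 is therefore estimated at 1.2 nM, within a range of 0.3 nM to 5 nM.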

Compound 3, inhibition constant: 0.5 nM
Beside the measured number, compound 3's estimate is 2.4-fold (0.38 log units) above it, within the range that was stated.
By their numbers in this assay, from the lowest: compounds 1 and 3 (each within the scatter of the next); then compound 2.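

In this assay, replacing 4-cyclohexylpiperazin-1-yl with isopentyloxy on the aromatic carbon meta to the trifluoromethyl group gives a 28-fold lower number from compound 2 to compound 3 (1.44 log units; beyond the scatter), so the low number at this position does not depend on dipropylamino alone: a second ring-free chain group, attached through oxygen rather than nitrogen, also gives a low number. The comparison of the two chain groups gives a 1.7-fold higher number from compound 1 to compound 3 (0.22 log units; within the scatter), which means that dipropylamino and isopentyloxy cannot be told apart on this read-out and that the change of linking atom has no readable effect in this pair. No accompanying measurement explains either step.

The change from 4-cyclohexylpiperazin-1-yl to isopentyloxy alters several features at once, including the rings, the heavy-atom count and the ring nitrogens, so the compounds shown leave open which of these goes with the higher number of compound 2. A cyclohexyloxy group, a morpholine ring or a shorter ethoxy chain at the same position would help separate these features and show how far the low numbers extend beyond these two chain groups.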